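Replacing Butyl with (3-Hydroxypropyl)amino on a Carbonyl Carbon

The compounds below may be only part of what the source reports. "The series", "measured", "known", "first", "only" and "open" are said of these compounds alone.

Going by the values given here, only two compounds have been tested so far in a functional assay on MCF7 cells (Homo sapiens) for antiproliferative activity, read by MTT assay, with a stated time of 72 h; a lower number here means a stronger inhibitor, a higher number a weaker inhibitor. In this assay, compound 1 `CCN(CC)CCNC(=O)c1ccc(C(CC)(CC)c2ccc(OCC(O)C(C)(C)C)c(C)c2)n1CC` gives 1370 nM, a measured number. Compound 2 `CCCCC(=O)c1ccc(C(CC)(CC)c2ccc(C#CC(O)(CC)CC)c(C)c2)n1CC` gives > 50000 nM, which is a limit of the assay and not a number. Compound 2 therefore stands at the limit of > 50000 nM in this assay, at which 1 of the 2 values shown sits.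

The next compound, compound 3 `CCn1c(C(=O)NCCCO)ccc1C(CC)(CC)c1ccc(C#CC(O)(CC)CC)c(C)c1`, has not yet been measured. It departs from compound 2 by one change: (3-hydroxypropyl)amino in place of butyl on a carbonyl carbon. In words, (3-hydroxypropyl)amino stands in place of butyl on a carbonyl carbon, so that butylcarbonyl becomes (3-hydroxypropyl)carbamoyl.

Among the compounds with values here, no measured step is available to size this change in this assay, and the starting point is itself only a limit. Compound 1, at 1370 nM, shows that a real number can be reached in this assay, so some movement toward stronger inhibition is expected, though its size remains uncertain. The estimated change is an at least 4.1-fold lower number from compound 2 to compound 3 (0.61 log units; beyond the scatter), in the direction of a lower number. For compound 3 the expected value is 12000 nM, with an estimated range from 2000 nM to 50000 nM.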

Compound 3, half-maximal inhibitory concentration: 5950 nM
Compound 3: middle estimate off by 2.0-fold (0.30 log units), on the high side, and the stated range covers the measured number.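

In this assay, going by these compounds alone, putting (3-hydroxypropyl)amino in place of butyl on a carbonyl carbon gives an at least 8.4-fold lower number from compound 2 to compound 3 (0.92 log units; beyond the scatter), so this position responds to the change, something the earlier compounds, with no step between them, could not show. The change turns butylcarbonyl into (3-hydroxypropyl)carbamoyl and brings hydrogen-bond donors and acceptors that butyl lacks, though this single step cannot tell whether they account for the difference. The size of the step is open-ended because compound 2 is held at a limit and not a number: the limit of > 50000 nM in this assay, at which 1 of the 3 values shown sits.

The compounds shown do not separate the part played by the amide nitrogen from that of the terminal hydroxyl, which a plain propylamino group on the same carbonyl carbon would help to settle. Also open, as far as these compounds go, is how far the trend extends along the chain, for example whether a longer hydroxyalkyl chain, a terminal amine or a carboxylic acid at the end of the propyl chain would move the number further in either direction.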